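From bromomethyl to iodomethyl on a shared core

The source may report more compounds than this note shows. Statements on the series, on what has been measured and on what is new or still open speak of the compounds shown alone.

In a functional assay on A-431 cells (Homo sapiens) for antiproliferative activity, read by sulforhodamine B assay, with a stated time of 72 h (on this read-out higher numbers stand for weaker inhibition and lower numbers for stronger inhibition), compound 1 (`C=C1CC(CBr)(c2ccccc2)OC1=O`) gives 1480 nM. For the measured compounds named here, only one close comparison exists: compound 2 (`C=C1CC(CBr)(c2ccccc2OC)OC1=O`) gives 2400 nM in this assay, and the two values lie within the scatter of each other. That step, with methoxy in place of hydrogen on an aromatic carbon, is a 1.6-fold higher number from compound 1 to compound 2 (0.21 log units; within the scatter).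

Compound 3 (`C=C1CC(CI)(c2ccccc2)OC1=O`) has yet to be measured. Its difference from compound 1 is iodo in place of bromo on a saturated chain carbon bound to a saturated ring carbon, or bromomethyl to iodomethyl when cut one bond further out. Going by the values given here, no measured pair changes this halogen, so the data offer no direct guide. Among the compounds with values here, the sole measured step, a 1.6-fold higher number from compound 1 to compound 2 (0.21 log units; within the scatter), lies elsewhere on the core and bears on the change only indirectly. Nothing therefore points to a shift beyond the scatter in this assay, in either direction. The expected change is a 1.0-fold higher number from compound 1 to compound 3 (0.01 log units; within the scatter). For compound 3 the estimated value is 1500 nM, with an expected range from 700 nM to 3200 nM.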

Compound 3, half-maximal inhibitory concentration: 2720 nM
The estimate for compound 3 lay 1.8-fold (0.26 log units) below the measured number; low and high end bracket the measured number.
By their numbers in this assay, from the lowest: compounds 1, 2 and 3 (each within the scatter of the next).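

For the compounds shown here, this is the first reading at the position on a saturated chain carbon bound to a saturated ring carbon, as the earlier step had touched only an aromatic carbon. In this assay, the exchange of bromo for iodo gives a 1.8-fold higher number from compound 1 to compound 3 (0.26 log units; within the scatter), so compound 1 and compound 3 cannot be told apart, and within this pair the read-out does not depend on bromo specifically being the halogen on this carbon. No accompanying measurement bears on why the two halogens read alike.

The compounds shown leave open whether this tolerance extends beyond bromo and iodo, for instance to chloro, a hydroxyl or an amine on the same carbon, or to a longer chain carrying the halogen. They also leave open how iodomethyl and a methoxy on an aromatic carbon would read together on the shared core, and whether the two halogens would stay equally close in a different cell line.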